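The source may hold more compounds than are shown below. What is called first, only, known or untested is meant among the compounds shown, and "the series" means these compounds.

Measured compounds, read in a functional assay on SK-BR-3 cells (Homo sapiens) for cytotoxicity, read by MTT assay, with a stated time of 72 h; a higher number here means that more compound is needed for the effect, a lower number that less compound is needed:
compound 1 `CCc1cccc2c(OC)c(-c3occ(C)c3CO)ccc12` gives 0.73 ug/mL.
compound 2 `CCOCc1c(C)coc1-c1ccc2c(CC)cccc2c1OC` gives > 10 ug/mL, a limit of the assay and not a number.
compound 3 `CCc1cccc2c(OC)c(-c3occ(C)c3COC(C)=O)ccc12` gives > 10 ug/mL, again a limit of the assay and not a number.

Compound 3 thus stands at the limit of this assay, and no number is known for it. Compound 2 sits at the same limit (the limit of > 10 ug/mL in this assay, at which 2 of the 3 values shown sit). Compound 1 alone gives a readable number. The two readable steps both start from compound 1: an at least 13-fold higher number from compound 1 to compound 2 (1.13 log units; beyond the scatter), and an at least 13-fold higher number from compound 1 to compound 3 (1.13 log units; beyond the scatter). Between the two capped compounds the step cannot be read: a step that the two limits leave unreadable from compound 2 to compound 3.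

Compound 4 `CCc1cccc2c(OC)c(-c3occ(C)c3COC(=O)CCN(CC)CC)ccc12` keeps the ester of compound 3 and differs from it only on the acetyl: (diethylamino)methyl in place of hydrogen on a saturated chain carbon bound to a carbonyl carbon. Going by the values given here, no measured step carries a change of this kind. What the measured steps do show is that any group placed on the hydroxyl oxygen of compound 1, ethyl or acetyl, costs a large amount in this assay, and compound 4 keeps such a group. Compound 4 is therefore expected to stay weak, near the limit, with the step from compound 3 not expected to exceed the scatter: an at least 1.2-fold lower number from compound 3 to compound 4 (0.09 log units; that floor lies within the scatter). Compound 4 is estimated at 8 ug/mL, in the range 2 ug/mL to 30 ug/mL.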

Compound 4, concentration for half-maximal effect: > 10 ug/mL
Compound 4 ended at the assay's limit; the forecaster's own chance of this, stated with the estimate: 45%; middle value at least 1.2-fold (0.09 log units) away from the limit.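

Replacing hydrogen with (2-(diethylamino)ethyl)carbonyl on the oxygen of compound 1 gives an at least 13-fold higher number from compound 1 to compound 4 (1.13 log units; beyond the scatter), so a third group on this oxygen, and the first shown to carry an amine, gives no readable number in this assay. Adding (diethylamino)methyl on the saturated chain carbon bound to a carbonyl carbon leaves the ester at the limit: compound 4 gives > 10 ug/mL, a limit of the assay and not a number. The steps from compound 2 and from compound 3 to compound 4 cannot be read, so the added chain can be neither ranked against ethyl or acetyl nor told apart from them, and the compounds with a group on this oxygen now share one limit: the limit of > 10 ug/mL in this assay, at which 3 of the 4 values shown sit.

From the compounds shown here alone, how far compound 2, compound 3 and compound 4 lie past that limit remains open, and with it any order among them. Also open, going by these compounds, is whether the free hydroxyl of compound 1 is itself required for a readable number in this assay, a question that a primary amine or a carboxylic acid in its place would address.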